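Benzylthio variants on the shared core: gastric cell inhibition

The compounds below may be only part of what the source reports. "The series", "measured", "known", "first", "only" and "open" are said of these compounds alone.

compound 1 `Cc1cc(Nc2cc(-c3ccccc3)[nH]n2)n2nc(SCc3ccc([N+](=O)[O-])cc3)nc2n1`: 43600 nM
compound 2 `Cc1cc(Nc2cc(-c3ccccc3)[nH]n2)n2ncnc2n1`: > 50000 nM
compound 3 `Cc1cc(Nc2cc(-c3ccccc3)[nH]n2)n2nc(SCc3c(Cl)cccc3Cl)nc2n1`: 39600 nM

In an ADME assay on GES1 cells (Homo sapiens) for inhibition, read by MTT assay, with a stated time of 72 h (a lower number here means a stronger inhibitor, a higher number a weaker inhibitor), compound 3 gives 39600 nM, the lowest of the two numbers shown, with compound 1 nearest at a 1.1-fold lower number from compound 1 to compound 3 (0.04 log units; within the scatter). Compound 2 reaches only the assay limit (the limit of > 50000 nM in this assay, at which 1 of the 3 values shown sits). The step to compound 3 reads an at least 1.2-fold lower number from compound 2 to compound 3 (0.10 log units; that floor lies within the scatter). Compound 4 `Cc1cc(Nc2cc(-c3ccccc3)[nH]n2)n2nc(SCc3csc4ccccc34)nc2n1` is not yet measured; its change from compound 3 is 1-benzothiophen-3-yl in place of 2,6-dichlorophenyl on a saturated chain carbon bound to a sulfur. The step that bears on it, the swap at the same position from compound 1 to compound 3, stayed within the scatter, and the addition of the whole group from compound 2 to compound 3 also stayed within it. For compound 4 a step of a 1.1-fold lower number from compound 3 to compound 4 (0.05 log units; within the scatter) is therefore expected, not beyond the scatter. Compound 4 is estimated at 35000 nM, between 15000 nM and 60000 nM.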

Compound 4, half-maximal inhibitory concentration: 29200 nM
Compound 4: middle estimate off by 1.2-fold (0.08 log units), on the high side; the measured number falls inside the stated range.
By their numbers in this assay, from the lowest: compounds 4, 3 and 1 (each within the scatter of the next). At a limit, above all of these: compound 2.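

In this assay, 1-benzothiophen-3-yl on the saturated chain carbon bound to a sulfur stays within the scatter of both earlier groups (a 1.4-fold lower number from compound 3 to compound 4 (0.13 log units; within the scatter); a 1.5-fold lower number from compound 1 to compound 4 (0.17 log units; within the scatter)). A second ring and a change from chlorine to a ring sulfur therefore give no readable shift at this position. Against compound 2, whose value is a limit of the assay, the step gives only a floor (an at least 1.7-fold lower number from compound 2 to compound 4 (0.23 log units; that floor lies within the scatter)).

As far as these compounds go, whether any group here can move the number beyond the scatter stays open. An amine or a carboxylic acid at this position would test that.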